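This account rests on a few compounds, and the source may have more. Where it says the series, first, only, none or still open, it means among the compounds named here.

Of the compounds shown here, two built on one shared core have so far been tested in a functional assay on RAW264.7 cells (Mus musculus) for inhibition; a lower number here means a stronger inhibitor, a higher number a weaker inhibitor. Compound 1 `O=C1/C(=C/c2ccc(C(F)(F)F)cc2)CCc2ccc(O)cc21` carries a trifluoromethyl group on its outer aromatic ring. In this assay compound 1 returns > 10000 nM, which is a limit of the assay and not a number (the limit of > 10000 nM in this assay, at which 1 of the 2 values shown sits). Compound 2 `O=C1/C(=C/c2ccc(Cl)cc2)CCc2ccc(O)cc21` carries a chloro group in the same place. In this assay, within the data shown here, compound 2 gives 1100 nM, the only actual number among the two values. The swap of chloro for trifluoromethyl produced an at least 9.0-fold lower number from compound 1 to compound 2 (0.95 log units; beyond the scatter).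

Compound 3 `O=C1/C(=C/c2ccc(Br)cc2)CCc2ccc(O)cc21` is the next member: it differs from compound 2 by bromo in place of chloro on an aromatic carbon. Among the measured compounds shown here, no measured step compares chloro with bromo; the one measured step, an at least 9.0-fold lower number from compound 1 to compound 2 (0.95 log units; beyond the scatter), concerns a different exchange and so bears only loosely on this one. Chloro and bromo are both single halogen atoms, and I therefore expect the step of a 1.2-fold lower number from compound 2 to compound 3 (0.09 log units; within the scatter) from compound 2 to compound 3 to stay within the usual scatter. My estimate for compound 3 in this assay is 900 nM, with a likely range from 400 nM to 2500 nM.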

Compound 3, half-maximal inhibitory concentration: 800 nM
Estimate against measurement, compound 3: 1.1-fold (0.05 log units) above; the measured number falls inside the stated range.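

In this assay, bromo in place of chloro gives a 1.4-fold lower number from compound 2 to compound 3 (0.14 log units; within the scatter) and so, at this place on the aromatic ring, para to a large group, the two halogens cannot be told apart. Bromo in place of trifluoromethyl gives an at least 12-fold lower number from compound 1 to compound 3 (1.09 log units; beyond the scatter) and this shows that the gain over the trifluoromethyl compound does not belong to chloro alone, but is shared by a second single halogen atom. The size of that step is a minimum and not an exact figure, because compound 1 carries a limit of the assay and not a number: the limit of > 10000 nM in this assay, at which 1 of the 3 values shown sits.

Still open, from the compounds shown here alone, is whether a group of a different kind at this place, such as a methoxy group, an amine or a carboxylic acid, would lower the number further, raise it or leave it unchanged, and whether fluoro or iodo would match chloro and bromo. Also open, going by these compounds, is how far trifluoromethyl truly lies from the two halogens, and whether bromo and chloro would still match each other elsewhere on the ring.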